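Cap exchange on the ring amine across two cores

A few compounds are considered here, and "the series" means these few. Any claim that something is new, unique, unknown or untested is made for them only; others in the source may bear on it.

Compound 1 `CC(C)(C)OC(=O)N1CCN(CC(=O)Nc2ccc(C(=O)/C=C/c3cn(Cc4ccc(Br)cc4)nn3)cc2)CC1` is the reference point; in a functional assay on A549 cells (Homo sapiens) for inhibition, read by MTT assay (a higher number here means a weaker inhibitor, a lower number a stronger inhibitor), compound 1 gives 38400 nM. Compound 2 `O=C(CN1CCN(c2ccc([N+](=O)[O-])cc2)CC1)Nc1ccc(C(=O)/C=C/c2cn(Cc3ccc(Br)cc3)nn2)cc1` differs from compound 1 by one change, (4-nitrophenyl in place of tert-butoxycarbonyl on an amine nitrogen in a ring), and in this assay compound 2 gives 45500 nM; the step is a 1.2-fold higher number from compound 1 to compound 2 (0.07 log units; within the scatter). Compound 3 `CCCCCCCCCCn1cc(/C=C/C(=O)c2ccc(NC(=O)CN3CCN(C(=O)OC(C)(C)C)CC3)cc2)nn1` carries a different core, the difference from compound 1 being (nonyl in place of 4-bromophenyl on a saturated chain carbon bound to an aromatic nitrogen). In this assay compound 3 gives 45400 nM, a step of a 1.2-fold higher number from compound 1 to compound 3 (0.07 log units; within the scatter) from compound 1.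

Compound 4 `CCCCCCCCCCn1cc(/C=C/C(=O)c2ccc(NC(=O)CN3CCN(c4ccc([N+](=O)[O-])cc4)CC3)cc2)nn1` has not yet been measured. It stands to compound 3 exactly as compound 2 stands to compound 1: the change is 4-nitrophenyl in place of tert-butoxycarbonyl on an amine nitrogen in a ring, and the surroundings of the place read word for word the same in both pairs, so it is the same change, not merely the same kind. Within the data shown here, with only one earlier instance, the expectation rests on that single step, a 1.2-fold higher number from compound 1 to compound 2 (0.07 log units; within the scatter), which stayed within the scatter. The step from compound 3 to compound 4 in this assay is accordingly expected to be a 1.1-fold higher number from compound 3 to compound 4 (0.06 log units; within the scatter). Compound 4 is thus estimated at 52000 nM, with a likely range from 26000 nM to 104000 nM.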

Compound 4, half-maximal inhibitory concentration: 64500 nM
The estimate for compound 4 lay 1.2-fold (0.09 log units) below the measured number; the range from low to high includes it.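

In this assay, 4-nitrophenyl in place of tert-butoxycarbonyl on the ring amine nitrogen gives a 1.4-fold higher number from compound 3 to compound 4 (0.15 log units; within the scatter), and this exchange carries over from the core of compound 1 to the core of compound 3 with no gap beyond the scatter: the same change on two cores in this assay, a 1.2-fold higher number (0.07 log units; within the scatter) from compound 1 to compound 2 and a 1.4-fold higher number (0.15 log units; within the scatter) from compound 3 to compound 4, 1.2-fold (0.08 log units) apart, within the scatter of two such steps. Read the other way, nonyl in place of 4-bromophenyl gives a 1.4-fold higher number from compound 2 to compound 4 (0.15 log units; within the scatter), and it too carries over from one cap to the other: the same change on two cores in this assay, a 1.2-fold higher number (0.07 log units; within the scatter) from compound 1 to compound 3 and a 1.4-fold higher number (0.15 log units; within the scatter) from compound 2 to compound 4, 1.2-fold (0.08 log units) apart, within the scatter of two such steps. Among these compounds, this agreement shows only that neither exchange moves the number beyond the scatter on either core; with all four steps this small and only two pairs for each exchange, it does not show that an effect of real size would transfer between cores.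

On these data alone, it remains open whether a different cap on the ring amine nitrogen, such as acetyl or methyl, or a shorter chain in place of nonyl, would give a step beyond the scatter. As far as these compounds go, whether such a step would then carry over between the two cores also remains open.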